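Swapping the amine-bearing chain on a shared coumarin-type amide scaffold

The source may hold more compounds than are shown below. What is called first, only, known or untested is meant among the compounds shown, and "the series" means these compounds.

Compound 1, `CC(=O)Oc1ccc(C(=O)Nc2cc3ccc(OCC4CCN(C)C4)c(C)c3oc2=O)cc1CC=C(C)C`, and compound 2, `CC(C)=CCc1cc(C(=O)Nc2cc3ccc(OCC4CCN(C)C4)c(C)c3oc2=O)ccc1O`, share one core and differ only in the group on the phenol-type oxygen. In a functional assay on SK-BR-3 cells (Homo sapiens) for antiproliferative activity (a higher number here means a weaker inhibitor, a lower number a stronger inhibitor), compound 1 gives 880 nM, and compound 2 gives 920 nM. For the measured compounds named here, the one measured step, a 1.0-fold higher number from compound 1 to compound 2 (0.02 log units; within the scatter), shows that exchanging these two groups on the aromatic oxygen leaves the number essentially where it was. Among the two values shown, compound 2 stands at the higher one, but the two are indistinguishable.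

Compound 3, `CCCN(CCC)CCCOc1ccc2cc(NC(=O)c3ccc(O)c(CC=C(C)C)c3)c(=O)oc2c1C`, keeps the whole amide and hydroxyl side of compound 2 and changes the other end: 2-(dipropylamino)ethyl in place of 1-methylpyrrolidin-3-yl on a saturated chain carbon bound to an oxygen on an aromatic ring. Going by the values given here, the only measured step concerns a different part of the molecule and therefore gives no direct guide to this change; it shows only that the scaffold tolerates at least one alteration without a shift beyond the scatter. With nothing bearing on the amine-bearing chain, compound 3 is expected to stay close to compound 2, with a step of a 1.1-fold higher number from compound 2 to compound 3 (0.04 log units; within the scatter), and the estimate for compound 3 is 1000 nM, ranging from 350 nM to 3000 nM.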

Compound 3, half-maximal inhibitory concentration: > 50000 nM
Compound 3 gave a limit, no number (the forecaster's own chance of this, stated with the estimate: 5%); at least 50-fold (1.69 log units) between middle value and limit.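

The amine-bearing chain proves far less forgiving than the group on the phenol-type oxygen: in this assay, replacing (1-methylpyrrolidin-3-yl)methoxy with 3-(dipropylamino)propoxy gives an at least 54-fold higher number from compound 2 to compound 3 (1.73 log units; beyond the scatter). This single step changes more than one feature at once, since the group that leaves has a five-membered non-aromatic ring and 6 heavy atoms, while the group that enters has no ring and 9 heavy atoms, though each carries 1 nitrogen. The size of the step can be stated only as a bound, because the result for compound 3 is a limit of the assay and not a number: the limit of > 50000 nM in this assay, at which 1 of the 3 values shown sits.

The compounds shown cannot tell whether opening the ring or adding the larger chain matters more, and a 3-(dimethylamino)propoxy chain or a 1-propylpyrrolidin-3-yl group on the same saturated chain carbon would help to pull those two features apart. On these data alone, it also remains open whether a 3-(dipropylamino)propoxy chain would have the same effect on the acetylated core of compound 1, or whether a non-amine chain such as a plain propoxy group would be tolerated at this position.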